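Hydrazone in Place of an Oxime Acetate

The source may report more compounds than this note shows. Statements on the series, on what has been measured and on what is new or still open speak of the compounds shown alone.

Two measured compounds share a core in which a trimethoxyphenyl group is joined to an indole by a carbon that carries a double bond. In a functional assay on HL-60 cells (Homo sapiens) for cytotoxicity, read by XTT assay, with a stated time of 72 h (a lower number here means a stronger inhibitor, a higher number a weaker inhibitor), compound 1 `CCn1ccc2cc(C(=O)c3ccc(OC)c(OC)c3OC)ccc21` gives 5000 nM. Compound 2 `COc1ccc(/C(=N\OC(C)=O)c2ccc3c(ccn3C)c2)c(OC)c1OC`, which carries an acetoxy on the double-bonded nitrogen, gives 580 nM in this assay, the lowest of the two numbers shown, and the gap to compound 1 is beyond the usual scatter. Compound 3 `COc1ccc(/C(=N\N)c2ccc3c(ccn3C)c2)c(OC)c1OC` differs from compound 2 in one place: amino in place of acetoxy on a double-bonded nitrogen. Among the compounds with values here, no step of this kind appears among the measured compounds, so the size of the change is open. With nothing beyond compound 2 to go on, the expected step from compound 2 to compound 3 is a modest loss, a 1.7-fold higher number from compound 2 to compound 3 (0.24 log units; within the scatter), though a step within the scatter would not surprise. Compound 3 is therefore expected to give about 1000 nM in this assay, within a range of 250 nM to 4000 nM.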

Compound 3, half-maximal inhibitory concentration: 2000 nM
For compound 3 the middle estimate is 2.0-fold (0.30 log units) below the measured one; low and high end bracket the measured number.
By their numbers in this assay, from the lowest: compound 2; then compound 3; then compound 1.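

In this assay, within the data shown here, amino in place of acetoxy on a double-bonded nitrogen gives a 3.4-fold higher number from compound 2 to compound 3 (0.54 log units; beyond the scatter), the first step that isolates this position. The group on this nitrogen therefore matters to the cytotoxicity read-out, and the acetoxy compares favourably with the amino. The acetoxy is not indispensable, though, since compound 3 still gives a finite 2000 nM. No measurement here accounts for the loss.

The compounds shown leave open whether the difference depends on the acetyl part as a whole or on the amino itself. A hydroxy or methoxy on the same nitrogen, or a longer acyloxy chain such as propionyloxy, would help to separate these possibilities.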